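The compounds below may be only part of what the source reports. "The series", "measured", "known", "first", "only" and "open" are said of these compounds alone.

Among the compounds with values here, in a functional assay on U-937 cells (Homo sapiens) for antiproliferative activity, read by MTT assay, with a stated time of 24 h (a higher number here means a weaker inhibitor, a lower number a stronger inhibitor), compound 1 (`CCCCc1oc2ccccc2c1C(=O)c1ccc(OCC(=O)Nc2cccc(OC)c2)cc1`) gives 24200 nM and compound 2 (`CCCCNC(=O)CCCOc1ccc(C(=O)c2c(CCCC)oc3ccccc23)cc1`) gives 24600 nM, so compound 2 stands level with the only other measured number. Compound 3 (`CCCCc1oc2ccccc2c1C(=O)c1ccc(OCCCC(=O)N2CCCC2)cc1`) carries pyrrolidin-1-yl in place of butylamino on a carbonyl carbon. Within the data shown here, the one measured step, a 1.0-fold higher number from compound 1 to compound 2 (0.01 log units; within the scatter), also altered the group on the saturated chain and stayed within the scatter, so no step beyond the scatter is expected in this assay. The expected step is a 1.0-fold lower number from compound 2 to compound 3 (0.01 log units; within the scatter). The estimated value for compound 3 is 24000 nM, with an expected range of 11000 nM to 50000 nM.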

Compound 3, half-maximal inhibitory concentration: 7500 nM
Compound 3: middle estimate off by 3.2-fold (0.51 log units), on the high side; the measured number lies below the stated range.
By their numbers in this assay, from the lowest: compound 3; then compounds 1 and 2 (each within the scatter of the next).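

In this assay, the group on the carbonyl carbon matters: pyrrolidin-1-yl in place of butylamino gives a 3.3-fold lower number from compound 2 to compound 3 (0.52 log units; beyond the scatter), whereas the earlier side-chain change stayed within the scatter. Replacing the whole (3-methoxyphenyl)carbamoyl group with 2-((pyrrolidin-1-yl)carbonyl)ethyl gives a similar result, a 3.2-fold lower number from compound 1 to compound 3 (0.51 log units; beyond the scatter). No available measurement accounts for these steps. On these data alone, it remains open whether the lower number goes with the five-membered ring or with the loss of the amide hydrogen. Dimethylamino and piperidin-1-yl on the same carbonyl carbon also remain open.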